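Truncating the side chain of compound 1

A few compounds are considered here, and "the series" means these few. Any claim that something is new, unique, unknown or untested is made for them only; others in the source may bear on it.

Three compounds of the series have numbers in an assay for inhibition of Indoleamine 2,3-dioxygenase 1 (Homo sapiens), read by fluorescence, with a stated time of 1 h; a lower number here means a stronger inhibitor, a higher number a weaker inhibitor. Compound 1 `NS(=O)(=O)NCCSc1nonc1/C(=N/O)Nc1ccc(F)c(Br)c1` gives 130 nM. Compound 2 `N#CCC(=O)NCCSc1nonc1/C(=N/O)Nc1ccc(F)c(C(F)F)c1` gives 180 nM, and the two values lie within the scatter of each other. Compound 3 `NS(=O)(=O)CC(=O)NCCSc1nonc1/C(=N/O)Nc1cccc(Br)c1` gives 30 nM, a lower number than compound 1, and that gap lies beyond the scatter. Compound 1 thus stands second highest of the three numbers shown, nearest to compound 2 and furthest from compound 3.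

Compound 4 `CSc1nonc1/C(=N/O)Nc1ccc(F)c(Br)c1` is not yet measured. Relative to compound 1 the change is hydrogen in place of (sulfamoylamino)methyl on a saturated chain carbon bound to a sulfur; cut one bond further out it reads 2-(sulfamoylamino)ethyl to methyl, or (2-(sulfamoylamino)ethyl)sulfanyl to methylsulfanyl. Among the compounds with values here, no pair of measured compounds differing in one place is available, so the size of this step has no direct precedent among the three. The change removes the hydrogen-bond donors and acceptors counted in the leaving group and shortens the chain to methylsulfanyl; the expectation is a higher number, a step beyond the scatter, estimated at a 5.4-fold higher number from compound 1 to compound 4 (0.73 log units; beyond the scatter). Compound 4 is expected to give about 700 nM in this assay, with a range from 200 nM to 3000 nM.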

Compound 4, half-maximal inhibitory concentration: 560 nM
The estimate for compound 4 lay 1.3-fold (0.10 log units) above the measured number, within the range that was stated.
By their numbers in this assay, from the lowest: compound 3; then compounds 1 and 2 (each within the scatter of the next); then compound 4.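

In this assay, within the data shown here, compound 1 and compound 4 give the first step that differs in one place: hydrogen in place of (sulfamoylamino)methyl on a saturated chain carbon bound to a sulfur brings a 4.3-fold higher number from compound 1 to compound 4 (0.63 log units; beyond the scatter). The side chain therefore counts at this place, though removing it still leaves compound 4 with a measurable 560 nM, so the number does not rest on the side chain alone. No measurement at hand bears on why the step has this size.

On these data alone, it remains open whether the step follows the sulfamoylamino group itself or simply the length of the chain; at this place, a plain ethyl, a 2-aminoethyl or a longer chain ending in a carboxylic acid would help separate those two readings. Compound 2 and compound 3 differ from compound 1 in more than one place, so the contributions of their side chains and of the groups on their aryl rings cannot yet be told apart.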